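A few compounds are considered here, and "the series" means these few. Any claim that something is new, unique, unknown or untested is made for them only; others in the source may bear on it.

Measured so far:
- compound 1, `O=C(CN1CCN(c2ccc(F)cc2)CC1)Nc1nc2c(s1)CCCCC2`, in an assay on isolated protein for inhibition of long-chain fatty acid transport protein 1 (Mus musculus), read by scintillation counting, with a stated time of 20 min; a higher number here means a weaker inhibitor, a lower number a stronger inhibitor: 2000 nM
- compound 2, `Cc1ccc(N2CCN(CC(=O)Nc3nc4c(s3)CCCC4)CC2)cc1`: > 10000 nM
- compound 3, `Cc1nc(NC(=O)CN2CCN(c3ccc(F)cc3)CC2)sc1C`: 1700 nM

Compound 1 and compound 3 both carry a 4-fluorophenyl group on the ring amine nitrogen and both return a measured half-maximal inhibitory concentration, with compound 1 at 2000 nM and compound 3 at 1700 nM. Compound 2 is the outlier among the three: in this assay compound 2 reaches only the limit of > 10000 nM, so for compound 2 no number exists, merely (the limit of > 10000 nM in this assay, at which 1 of the 3 values shown sits).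

Compound 4, `O=C(CN1CCN(c2nccs2)CC1)Nc1nc2c(s1)CCCC2`, has not yet been tested in this assay. It differs from compound 2 in one place: 1,3-thiazol-2-yl in place of 4-methylphenyl on an amine nitrogen in a ring. The shared core of compound 2 and compound 4 is the same, and the linker is unchanged.

Among the compounds with values here, no measured step connects compound 2 to anything else, so the size of the change in this assay can only be guessed from where compound 2 stands. Within the data shown here, since compound 2 sits at the limit, the step to compound 4 is expected to be a gain in inhibition or no step at all, because a loss cannot be seen from the limit of > 10000 nM in this assay, at which 1 of the 3 values shown sits. Compound 4 is estimated at 5000 nM, with a range from 1500 nM to 20000 nM. That estimate implies a step of an at least 2.0-fold lower number from compound 2 to compound 4 (0.30 log units; that floor lies within the scatter), with a real chance that compound 4 also stays at the limit.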

Compound 4, half-maximal inhibitory concentration: 7900 nM
Estimate against measurement, compound 4: 1.6-fold (0.20 log units) below; the range from low to high includes it.
By their numbers in this assay, from the lowest: compounds 3 and 1 (each within the scatter of the next); then compound 4. At a limit, above all of these: compound 2.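

In this assay, compound 4 gives a measured value of 7900 nM, showing that the amine nitrogen in the six-membered non-aromatic ring can carry 1,3-thiazol-2-yl, a five-membered aromatic ring with 2 hetero atoms, and still yield a number on this shared core. Compound 2 offers only a limit in this assay, > 10000 nM, and not a number. Replacing 4-methylphenyl with 1,3-thiazol-2-yl therefore reads as an at least 1.2-fold lower number from compound 2 to compound 4 (0.10 log units; that floor lies within the scatter), and this is only a floor, because the starting value is a limit: the limit of > 10000 nM in this assay, at which 1 of the 4 values shown sits.

The compounds shown leave open how large the step truly is and whether it follows from the hetero atoms of the new ring or simply from the loss of 4-methylphenyl. A plain phenyl or a pyridin-2-yl group on the same ring nitrogen and the same core would help separate these two readings, since each would keep a six-membered aromatic ring in that place.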